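The source may hold more compounds than are shown below. What is called first, only, known or untested is meant among the compounds shown, and "the series" means these compounds.

Measured compounds in a functional assay on A549 cells (Homo sapiens) for antiproliferative activity, read by MTT assay, with a stated time of 48 h; a higher number here means a weaker inhibitor, a lower number a stronger inhibitor:

Compound 1 `O=C(/C=C\Nc1ccc(C(F)(F)F)cc1)c1cn(-c2ccccc2)nc1-c1ccc(F)cc1` gives > 50000 nM, which is a limit of the assay.
Compound 2 `O=C(/C=C\Nc1ccc(O)cc1)c1cn(-c2ccccc2)nc1-c1ccc(F)cc1` gives 1500 nM.
Compound 3 `COc1ccc(-c2nn(-c3ccccc3)cc2C(=O)/C=C\Nc2ccc(C(F)(F)F)cc2)cc1` gives > 50000 nM, which is a limit of the assay.

Compound 4 `COc1ccc(-c2nn(-c3ccccc3)cc2C(=O)/C=C\Nc2ccc(O)cc2)cc1` has not been measured in this assay.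

The series holds two cores. Compound 3 differs from compound 1 by methoxy in place of fluoro on an aromatic carbon. The step between them in this assay is a step that the two limits leave unreadable from compound 1 to compound 3, so how much the core change matters is not readable here, because of the limit of > 50000 nM in this assay, at which 2 of the 3 values shown sit.

On the core of compound 1, the change hydroxy in place of trifluoromethyl on an aromatic carbon gives an at least 33-fold lower number from compound 1 to compound 2 (1.52 log units; beyond the scatter). The same change is made on the core of compound 3, as hydroxy in place of trifluoromethyl on an aromatic carbon, and the place lines of the two changes agree word for word, so it is the same change, made on a core that differs only as described above.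

For compound 4 the step in this assay is expected to be an at least 16-fold lower number from compound 3 to compound 4 (1.22 log units; beyond the scatter), resting on the step from compound 1 to compound 2, an at least 33-fold lower number from compound 1 to compound 2 (1.52 log units; beyond the scatter), since compound 3 sits at the same limit as compound 1 and the core difference, a step that the two limits leave unreadable from compound 1 to compound 3, does not show a readable effect. Compound 4 is therefore estimated at 3000 nM in this assay, between 800 nM and 30000 nM, with some chance that only a limit is returned.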

Compound 4, half-maximal inhibitory concentration: 2770 nM
Compound 4: middle estimate off by 1.1-fold (0.03 log units), on the high side; measured number inside the range.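

In this assay the replacement of trifluoromethyl by hydroxy carries over to the second core, with an at least 18-fold lower number from compound 3 to compound 4 (1.25 log units; beyond the scatter), and the change runs in the same direction on both cores: the same change on two cores in this assay, an at least 33-fold lower number (1.52 log units; beyond the scatter) from compound 1 to compound 2 and an at least 18-fold lower number (1.25 log units; beyond the scatter) from compound 3 to compound 4; the limit leaves it open whether they differ. For the compounds shown here, with hydroxy present on both cores, the core change can be read for the first time, as a 1.8-fold higher number from compound 2 to compound 4 (0.27 log units; within the scatter), so this assay does not separate compound 2 from compound 4. The true size of the hydroxy step on either core remains unreadable, as does the core change among the trifluoromethyl compounds, since each of those steps starts from a limit of the assay rather than a number: the limit of > 50000 nM in this assay, at which 2 of the 4 values shown sit.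

Going by these compounds, only trifluoromethyl and hydroxy stand on this aromatic carbon, so it stays open whether an amine or a carboxylic acid there would behave like hydroxy. On these data alone, only fluoro and methoxy mark the two cores, so it also stays open whether the agreement between compound 2 and compound 4 would hold with a chloro group or a longer alkoxy chain in their place.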